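The compounds below may be only part of what the source reports. "The series", "measured", "known", "first", "only" and "open" are said of these compounds alone.

The study compares two measured compounds in an assay on isolated protein for binding affinity to sphingosine 1-phosphate receptor 2 (Homo sapiens), read by surface plasmon resonance (on this read-out higher numbers stand for weaker binding and lower numbers for tighter binding), and then asks what a third, so far unmeasured, compound should give. Compound 1, `Cc1nn(C)c2nc(NNC(=O)Nc3cc(Cl)nc(Cl)c3)cc(-c3ccc(F)cc3)c12`, shows the lower of the two numbers: in this assay compound 1 gives 980 nM. Compound 2, `COc1ccc(-c2cc(NNC(=O)Nc3cc(Cl)nc(OC)c3)nc3c2cnn3C)cc1`, shows the higher number, and in this assay compound 2 gives 1980 nM, a gap that lies beyond the usual scatter. The two compounds differ in more than one place, so no single change can be held responsible for that gap.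

Compound 3, `Cc1nn(C)c2nc(NNC(=O)Nc3cc(Cl)nc(Cl)c3)cc(-c3ccccc3)c12`, differs from compound 1 in one place only: hydrogen in place of fluoro on an aromatic carbon. The group that leaves is small, it carries no heavy atom besides the fluorine itself, no ring, no donor and no acceptor, and the place is on the aromatic carbon para to a large group. Within the data shown here, no step of this kind has been measured here, so the expectation rests on the size of the change alone. The step from compound 1 to compound 3 is expected to be small, a 1.2-fold higher number from compound 1 to compound 3 (0.09 log units; within the scatter), and is not expected to move beyond the scatter in either direction. Compound 3 is therefore estimated to give 1200 nM in this assay, with a range from 500 nM to 3000 nM.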

Compound 3, dissociation constant: 5320 nM
Compound 3: middle estimate off by 4.4-fold (0.65 log units), on the low side; the whole stated range lies below it.
By their numbers in this assay, from the lowest: compound 1; then compound 2; then compound 3.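

In this assay, replacing the fluoro of the 4-fluorophenyl group with hydrogen gives a 5.4-fold higher number from compound 1 to compound 3 (0.73 log units; beyond the scatter), so a single atom on this aromatic carbon, para to a large group, moves the number beyond the scatter. Among these compounds, this is the first effect that can be assigned to one place, since compound 1 and compound 2 differ in more than one place and their gap could be assigned to none of them alone. The data at hand offer no explanation for this step.

As far as these compounds go, it remains open whether the step is particular to fluoro: a nitrile or an amine on the same aromatic carbon could give a number close to that of compound 1, close to that of compound 3, or unlike either. Also open is whether the step would keep its size with other groups elsewhere on the shared core, as the compounds shown contain this change only once.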